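A few compounds are considered here, and "the series" means these few. Any claim that something is new, unique, unknown or untested is made for them only; others in the source may bear on it.

Measured compounds, in an assay on Jurkat cells for inhibition of cyclic AMP-dependent transcription factor ATF-1 (Homo sapiens); on this read-out lower numbers stand for stronger inhibition and higher numbers for weaker inhibition:

- compound 1, `O=C(Nc1cc(Cl)cc(Cl)c1)c1cnc(O)nc1C(F)(F)F`, gives > 10000 nM, which is a limit of the assay and not a number
- compound 2, `CN(C(=O)c1cnc(Cl)nc1C(F)(F)F)c1cc(Cl)cc(Cl)c1`, gives 3000 nM
- compound 3, `O=C(Nc1cc(C(F)(F)F)cc(C(F)(F)F)c1)c1cnc(Cl)nc1C(F)(F)F`, gives 50 nM

Compound 3 has the lowest of the two numbers that were actually obtained; the nearest number is that of compound 2, and the gap between them is well beyond the usual scatter of repeated measurements. Compound 1 reaches only the limit of the assay, as described in the limit of > 10000 nM in this assay, at which 1 of the 3 values shown sits. Compound 4, `CCCCNC(=O)c1cc(NC(=O)c2cnc(Cl)nc2C(F)(F)F)cc(C(F)(F)F)c1`, has not yet been measured in this assay. It differs from compound 3 in one place: butylcarbamoyl in place of trifluoromethyl on an aromatic carbon. For the measured compounds named here, no measured pair shows this kind of change, so the size of the step can only be guessed. A butylcarbamoyl group brings a hydrogen-bond donor and a hydrogen-bond acceptor where the trifluoromethyl group of compound 3 carried neither, and the whole attached group becomes larger. The step from compound 3 to compound 4 in this assay is expected to be modest, towards a higher number, and estimated at a 4.0-fold higher number from compound 3 to compound 4 (0.60 log units; beyond the scatter). Compound 4 is therefore expected to give about 200 nM, within a range from 40 nM to 2000 nM.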

Compound 4, half-maximal inhibitory concentration: > 10000 nM
Compound 4 gave a limit, no number; the forecaster's own chance of this, stated with the estimate: 10%; middle value at least 50-fold (1.69 log units) away from the limit.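

In this assay, for the compounds shown here, placing butylcarbamoyl instead of trifluoromethyl on this aromatic carbon gives an at least 200-fold higher number from compound 3 to compound 4 (2.30 log units; beyond the scatter), a large step and the first one between two compounds that differ in one place. It shows that the group at this position has a strong effect on the read-out, and that this larger group with a hydrogen-bond donor and acceptor costs far more here than a modest change would. Compound 4 reaches a limit of the assay and not a number, so the step has no upper end, and compound 4 is not alone at that limit: the limit of > 10000 nM in this assay, at which 2 of the 4 values shown sit.

The compounds shown do not tell whether the amide hydrogen, the carbonyl or the length of the butyl chain matters most. A methylcarbamoyl group, a plain butyl chain or a carboxylic acid on this carbon would help to separate these parts.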